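A few compounds are considered here, and "the series" means these few. Any claim that something is new, unique, unknown or untested is made for them only; others in the source may bear on it.

Measured so far in a functional assay on MDA-MB-468 cells (Homo sapiens) for antiproliferative activity; a lower number here means a stronger inhibitor of growth, a higher number a weaker inhibitor of growth
- compound 1 `COc1ccc(-c2nc3ccccc3s2)cc1OC` gives 530 nM
- compound 2 `COc1ccc(-c2nc3cc(F)ccc3s2)cc1OC` gives < 0.1 nM which is a limit of the assay and not a number
- compound 3 `COc1ccc(-c2nc3cc(Cl)ccc3s2)cc1OC` gives 1000 nM

Within the data shown here, compound 1 holds one of only two numeric values, and the other stays within the scatter of it, with a 1.9-fold higher number from compound 1 to compound 3 (0.28 log units; within the scatter). Compound 2 lies far from both and sits at the limit of the assay (the limit of < 0.1 nM in this assay, at which 1 of the 3 values shown sits).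

Compound 4 `COc1ccc(-c2nc3ccc(F)cc3s2)cc1OC` is the next case, with fluoro in place of hydrogen on an aromatic carbon of the core of compound 1 (fluoro in place of hydrogen on an aromatic carbon). Among the measured compounds shown here, the closest precedent is the same exchange at a different aromatic carbon, which gives an at least 5300-fold lower number from compound 1 to compound 2 (3.72 log units; beyond the scatter). Chloro at that carbon gives no change beyond the scatter, and an at least 10000-fold higher number from compound 2 to compound 3 (4.00 log units; beyond the scatter) shows how sharply the outcome turns on a single atom. Three compounds define no rule for a new position, so the full gain of compound 2 is not carried over to compound 4. A moderate move towards lower numbers in this assay is expected, with wide uncertainty. The estimated step is an 11-fold lower number from compound 1 to compound 4 (1.03 log units; beyond the scatter). For compound 4 the expected value is 50 nM with an estimated range from 1 nM to 2000 nM.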

Compound 4, concentration for 50% growth inhibition: 5 nM
For compound 4 the middle estimate is 10-fold (1.00 log units) above the measured one, within the range that was stated.
By their numbers in this assay, from the lowest: compound 4; then compounds 1 and 3 (each within the scatter of the next). At a limit, below all of these: compound 2.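

In this assay, fluoro in place of hydrogen at this second aromatic carbon, meta to a fused ring and para to a fused ring, also moves the number far beyond the scatter, with a 110-fold lower number from compound 1 to compound 4 (2.03 log units; beyond the scatter). The large drop is therefore not tied to a single aromatic carbon of the shared core, since fluoro lowers the number at both carbons shown, although compound 3 goes against any wider rule for halogens, with a 1.9-fold higher number from compound 1 to compound 3 (0.28 log units; within the scatter). The value of compound 2 is a limit of the assay and not a number, so the two fluoro positions cannot be ranked by size of step: the limit of < 0.1 nM in this assay, at which 1 of the 4 values shown sits.

Open, as far as these compounds go, is whether the lower number of compound 4 belongs to fluoro alone, or whether chloro, a nitrile or an amine on the same aromatic carbon would keep it. Also open, from the compounds shown here alone, is whether the effect of fluoro depends on the two methoxy groups of the core of compound 1, for instance if they gave way to ethoxy or a longer chain.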